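This account rests on a few compounds, and the source may have more. Where it says the series, first, only, none or still open, it means among the compounds named here.

Measured compounds:
compound 1 `COc1ccc(-n2nc(C(N)=O)nc2-c2cc(OC)c(OC)c(OC)c2)cc1` – 64%
compound 2 `COc1ccc(-n2nc(C(=O)Nc3ccc(C(F)(F)F)cc3)nc2-c2cc(OC)c(OC)c(OC)c2)cc1` – 50%

In a functional assay on the whole organism for inhibition, with Rattus norvegicus as the target, read by paw edema, with stated times of 30 min and 5 h, at a dose of 0.28 mmol/kg by the oral route (a higher number here means more inhibition at the dose given (going by the name of the read-out), a lower number less inhibition), compound 2 stands lowest of the two numbers; its nearest neighbour is compound 1, and the step of a number 14 percentage points lower from compound 1 to compound 2 (beyond the scatter) is beyond the scatter. Compound 3 `COc1ccc(-n2nc(C(=O)Nc3ccccc3)nc2-c2cc(OC)c(OC)c(OC)c2)cc1` differs from compound 2 by hydrogen in place of trifluoromethyl on an aromatic carbon, that is, 4-(trifluoromethyl)phenyl to phenyl. Among the measured compounds shown here, the only step that bears on it is a number 14 percentage points lower from compound 1 to compound 2 (beyond the scatter), which put the whole 4-(trifluoromethyl)phenyl onto the amide-type nitrogen; removing the trifluoromethyl alone is a smaller change, so only a partial return toward compound 1 is expected. For compound 3 the expected step is a number 6 percentage points higher from compound 2 to compound 3 (within the scatter), within the scatter. Compound 3 is estimated at 56%, range 42% to 70%.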

Compound 3, a percentage reported as inhibition, in the whole organism at one dose (the size of the read-out at that dose, not a potency): 46%
Compound 3: middle estimate off by 10 percentage points, on the high side; the measured number falls inside the stated range.
By their numbers in this assay, from the lowest: compounds 3 and 2 (each within the scatter of the next); then compound 1.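

In this assay the exchange of trifluoromethyl for hydrogen on this aromatic carbon gives a number 4 percentage points lower from compound 2 to compound 3 (within the scatter) and does not separate the two groups. The plain phenyl on the amide-type nitrogen gives a number 18 percentage points lower from compound 1 to compound 3 (beyond the scatter) in its turn, so the step away from compound 1 needs no trifluoromethyl. Nothing measured on hand accounts for either step.

Open, from the compounds shown here alone, is whether a methoxy group or an amine on this aromatic carbon would stand apart from hydrogen. Also open, going by these compounds, is whether a methyl group on the amide-type nitrogen would stay level with compound 1.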